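The compounds below may be only part of what the source reports. "The series", "measured", "known", "first", "only" and "open" are said of these compounds alone.

In an ADME assay on C8166 cells (Homo sapiens) for cytotoxicity, read by MTT assay (a lower number here means that less compound is tolerated, a higher number that more compound is tolerated), three compounds with a shared core have been measured, and they differ only in the group on an aromatic nitrogen. Compound 1 `CCCn1cc(C(=O)O)c(=O)c2c(O)c(Cc3cccc(Cl)c3F)ccc21`, with propyl, gives 24200 nM. Compound 2 `CCCCn1cc(C(=O)O)c(=O)c2c(O)c(Cc3cccc(Cl)c3F)ccc21`, with butyl, gives 20000 nM, and the change between these two is a 1.2-fold lower number from compound 1 to compound 2 (0.08 log units; within the scatter). Compound 3 `CC(C)(C)n1cc(C(=O)O)c(=O)c2c(O)c(Cc3cccc(Cl)c3F)ccc21`, with tert-butyl, gives 400000 nM, the highest of the three numbers.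

Compound 4 `O=C(O)c1cn(C2CC2)c2ccc(Cc3cccc(Cl)c3F)c(O)c2c1=O` has cyclopropyl in place of tert-butyl on an aromatic nitrogen. Among the measured compounds shown here, the steps that bear on this change are the two that introduced tert-butyl: a 17-fold higher number from compound 1 to compound 3 (1.22 log units; beyond the scatter) and a 20-fold higher number from compound 2 to compound 3 (1.30 log units; beyond the scatter). For the measured compounds named here, both are large, yet no measured compound has a ring on that nitrogen, so the data do not place cyclopropyl directly. Removing tert-butyl may give back much of that gain, though perhaps not all of it. The expected change is a 6.7-fold lower number from compound 3 to compound 4 (0.82 log units; beyond the scatter), a clear move towards the straight-chain compounds. The estimated value for compound 4 is 60000 nM, with an expected range from 15000 nM to 250000 nM.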

Compound 4, half-maximal cytotoxic concentration: 39100 nM
The estimate for compound 4 lay 1.5-fold (0.19 log units) above the measured number, within the range that was stated.
By their numbers in this assay, from the lowest: compounds 2, 1 and 4 (each within the scatter of the next); then compound 3.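

In this assay the change from tert-butyl to cyclopropyl gives a 10-fold lower number from compound 3 to compound 4 (1.01 log units; beyond the scatter) and so removes nearly all of the high number seen with compound 3. The ring also lands among the straight chains, with a 1.6-fold higher number from compound 1 to compound 4 (0.21 log units; within the scatter) and a 2.0-fold higher number from compound 2 to compound 4 (0.29 log units; within the scatter) both within the scatter, so among these four groups on the aromatic nitrogen only tert-butyl stands apart. Nothing available here explains why tert-butyl behaves differently.

Isopropyl, a branched group with fewer carbons than tert-butyl, and cyclohexyl, a larger carbon ring, lie outside these compounds. Going by these compounds, it therefore remains open whether the high number of compound 3 goes with branching in general or with tert-butyl alone.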